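The source may report more compounds than this note shows. Statements on the series, on what has been measured and on what is new or still open speak of the compounds shown alone.

Measured so far:
compound 1, `O=C(O)c1cnc2cc(O)ccc2c1O` — 955000 nM
compound 2, `O=C(O)c1cnc2cc(OCCc3ccccc3)ccc2c1O` — 155000 nM

In an assay on isolated protein with malate dehydrogenase, cytoplasmic (Sus scrofa) as the target (a lower number here means a stronger inhibitor, a higher number a weaker inhibitor), compound 1 gives 955000 nM, the highest number of the two. Compound 2 gives 155000 nM, a lower number and beyond the scatter. Compound 3, `NS(=O)(=O)c1ccc2c(O)c(C(=O)O)cnc2c1`, differs from compound 1 by sulfamoyl in place of hydroxy on an aromatic carbon. Within the data shown here, no measured pair shows this kind of change, so the expectation rests on compound 1 alone. The change is expected to move the number only modestly, with a slight lowering, so the step from compound 1 to compound 3 is estimated as a 1.6-fold lower number from compound 1 to compound 3 (0.20 log units; within the scatter). Compound 3 is accordingly expected to give 600000 nM, within a range of 150000 nM to 2000000 nM.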

Compound 3, half-maximal inhibitory concentration: 692000 nM
Beside the measured number, compound 3's estimate is 1.2-fold (0.06 log units) below it; the range from low to high includes it.
By their numbers in this assay, from the lowest: compound 2; then compounds 3 and 1 (each within the scatter of the next).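

In this assay sulfamoyl in place of hydroxy on an aromatic carbon gives a 1.4-fold lower number from compound 1 to compound 3 (0.14 log units; within the scatter) and so leaves the number within the scatter. This position therefore accepts a group of 4 heavy atoms in place of the hydroxy of compound 1 with no readable change in inhibition. Nothing measured accounts for this step. Still open, on these data alone, is whether an amine or a carboxylic acid at this position would move the number beyond the scatter. Also open, as far as these compounds go, is whether a sulfamoyl carrying a longer chain on its nitrogen would do so.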